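This account rests on a few compounds, and the source may have more. Where it says the series, first, only, none or still open, it means among the compounds named here.

Measured so far:
- Compound 1 `CCOc1ccc(Br)cc1-c1cc(Nc2ccc(C(C)=O)cc2)nc(N)n1`: 90 nM
- Compound 2 `Cc1ccc(Cl)cc1-c1cc(Nc2ccc(C(F)(F)F)cc2)nc(N)n1`: 230 nM

Among the measured compounds shown here, in a functional assay on DU-145 cells (Homo sapiens) for inhibition (on this read-out lower numbers stand for stronger inhibition and higher numbers for weaker inhibition), compound 1 gives 90 nM, the lower of the two numbers so far. Compound 2 reads 230 nM, and this gap lies beyond the usual scatter of repeat measurements. These two compounds differ in more than one place, however, so their gap cannot be tied to any single change.

The next compound, compound 3 `CCOc1ccc(Br)cc1-c1cc(Nc2ccc(Cl)cc2)nc(N)n1`, keeps the core of compound 1 and has chloro in place of acetyl on an aromatic carbon. For the measured compounds named here, no measured pair here differs in one place only, so the data offer no direct guide to this swap. The only weak hint is that compound 2, which also lacks the acetyl, reads 230 nM. A modest shift towards weaker inhibition therefore seems more likely than a large move either way, though no change beyond the scatter remains possible. The expected size of the change is a 2.0-fold higher number from compound 1 to compound 3 (0.30 log units; within the scatter). For compound 3, the estimated value is 180 nM, with an expected range from 60 nM to 550 nM.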

Compound 3, half-maximal inhibitory concentration: 80 nM
Beside the measured number, compound 3's estimate is 2.3-fold (0.35 log units) above it, within the range that was stated.
By their numbers in this assay, from the lowest: compounds 3 and 1 (each within the scatter of the next); then compound 2.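

Among the compounds shown here, compound 3 gives the first comparison here that changes one place only: the 4-acetylphenyl of compound 1 becomes 4-chlorophenyl, with the rest of the molecule kept. In this assay this swap gives a 1.1-fold lower number from compound 1 to compound 3 (0.05 log units; within the scatter) and therefore shows no real difference, so for this pair the acetyl group, with its double bond and hydrogen-bond acceptor, is not required to keep the read-out in this range, and the much smaller chloro, which has no hydrogen-bond acceptor, serves as well. Nothing measured here explains why these two different groups read alike.

This single pair cannot show how far the position tolerates change, since an amine, a carboxylic acid or a longer chain such as butyl in the same place could read quite differently. Going by these compounds, compound 2 carries trifluoromethyl at this position but also differs from compound 3 on the other aromatic ring, so its number cannot be tied to either change, and whether chloro and acetyl would also read alike with other groups on that ring remains open.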